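This account rests on a few compounds, and the source may have more. Where it says the series, first, only, none or still open, it means among the compounds named here.

Working notes on a short series of bromoalkoxy pyrimidine bis-styryl compounds, read in a functional assay on HCT-116 cells (Homo sapiens) for cytotoxicity, read by fluorescence and resazurin assay, with a stated time of 48 h; a lower number here means a stronger inhibitor, a higher number a weaker inhibitor.

Compound 1 `COc1ccc(/C=C/c2cc(/C=C/c3ccc(OC)cc3)nc(OCCCCCBr)n2)cc1` carries the longer bromoalkoxy chain on the core that bears two methoxy-substituted styryl arms. In this assay compound 1 gives only a limit of the assay, > 20000 nM, not a number. Compound 2 `COc1ccc(/C=C/c2cc(/C=C/c3ccc(OC)cc3)nc(OCCCCBr)n2)cc1` is the same core with the chain shortened; the change is bromo in place of bromomethyl on a saturated chain carbon, four bonds along the chain from an oxygen on an aromatic ring. In this assay compound 2 likewise reaches only a limit, > 20000 nM. The step between them is therefore a step that the two limits leave unreadable from compound 1 to compound 2, and nothing more can be said of its size.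

Compound 3 `BrCCCCCCOc1nc(/C=C/c2ccccc2)cc(/C=C/c2ccccc2)n1` has the unsubstituted styryl arms and a longer bromoalkoxy chain. The difference between the core of compound 3 and the core of compound 1 is not broken down here. In this assay compound 3 again returns a limit of the assay, > 20000 nM. Taken together, the limit of > 20000 nM in this assay, at which 3 of the 3 values shown sit, is the whole picture so far.

Compound 4 `BrCCCCCOc1nc(/C=C/c2ccccc2)cc(/C=C/c2ccccc2)n1`, to be measured in this assay, differs from compound 3 by bromo in place of bromomethyl on a saturated chain carbon, five bonds along the chain from an oxygen on an aromatic ring. This is the same kind of change as that from compound 1 to compound 2, but the place differs: there the bromo sits four bonds along the chain from the oxygen on the aromatic ring, here five bonds along. Because the limit of > 20000 nM in this assay, at which 3 of the 3 values shown sit, holds for every value shown, including the pair around the matching change, the step from compound 3 to compound 4 is expected to stay unreadable, roughly a step that the limit leaves unreadable from compound 3 to compound 4. Compound 4 is estimated at 30000 nM, with a range of 15000 nM to 80000 nM, most likely returned as a limit again.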

Compound 4, half-maximal inhibitory concentration: > 20000 nM
Compound 4: a limit, no number; the forecaster's own chance of this, stated with the estimate: 85%; the middle value does not contradict the limit.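

Compound 3 and compound 4 both return only a limit of the assay in this assay, so no step can be read between them. The series stays at a single limit: the limit of > 20000 nM in this assay, at which 4 of the 4 values shown sit. With no number among these compounds, what they leave open is how the bromoalkoxy chain or the styryl arms bear on cytotoxicity in this assay.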